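The compounds below may be only part of what the source reports. "The series", "measured", "known", "first", "only" and "open" are said of these compounds alone.

In a functional assay (aorta) with Oryctolagus cuniculus as the target (a lower number here means tighter binding, a higher number weaker binding), compound 2 `COc1ccc(OCCCN2CCC(C(c3ccc(F)cc3)c3ccc(F)cc3)CC2)cc1` gives 2.51 nM, the lower of the two numbers, while compound 1 `NC(=O)c1ccc(OCCCN2CCC(C(c3ccc(F)cc3)c3ccc(F)cc3)CC2)cc1` gives 31.6 nM. Compound 3 `COc1ccccc1OCCCN1CCC(C(c2ccc(F)cc2)c2ccc(F)cc2)CC1` follows from 2-methoxyphenyl in place of 4-methoxyphenyl on an oxygen on a saturated carbon. Among the measured compounds shown here, the only measured step, a 13-fold lower number from compound 1 to compound 2 (1.10 log units; beyond the scatter), is large, but it replaces carbamoyl with methoxy and does not relocate methoxy, so it bears only indirectly. No step beyond the scatter is therefore expected in this assay, with a slight lean toward a higher number. The expected change is a 1.6-fold higher number from compound 2 to compound 3 (0.20 log units; within the scatter). For compound 3 the estimated value is 4 nM, with an expected range of 0.8 nM to 16 nM.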

Compound 3, dissociation constant: 2.51 nM
For compound 3 the middle estimate is 1.6-fold (0.20 log units) above the measured one; low and high end bracket the measured number.
By their numbers in this assay, from the lowest: compounds 2 and 3 (each within the scatter of the next); then compound 1.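

In this assay, 2-methoxyphenyl in place of 4-methoxyphenyl gives no change at the digits printed from compound 2 to compound 3 (within the scatter), so the two methoxyphenyl groups on this oxygen cannot be told apart here. With 2-methoxyphenyl in place of 4-carbamoylphenyl the series shows a 13-fold lower number from compound 1 to compound 3 (1.10 log units; beyond the scatter), so the large gap to compound 1 holds for both methoxyphenyl groups. No data on hand explain this result. Still open, from the compounds shown here alone, is whether ethoxy, hydroxy or a carboxylic acid in place of methoxy would keep the number this low. Going by these compounds, a longer chain on the oxygen is equally open.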